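This account rests on a few compounds, and the source may have more. Where it says the series, first, only, none or still open, it means among the compounds named here.

Compound 1 `CN1C[C@H]2C=C(c3cccnc3)C[C@H](C2)C1` gives 27% in a functional assay on synaptosomes from brain (strain Sprague-Dawley) for agonist activity at Nicotinic acetylcholine receptor alpha6/alpha3/beta2/beta3 (Rattus norvegicus); on this read-out higher numbers stand for larger maximal responses and lower numbers for smaller maximal responses.
Compound 2 `C1=C(c2cccnc2)C[C@@H]2CNC[C@H]1C2` gives 49% in this assay.

Compound 2 stands highest of these two numbers; the gap to compound 1 lies beyond the usual scatter. Compound 3 `CN1C[C@@H]2C=C(c3cccnc3)C[C@@H](C2)C1` differs from compound 2 by methyl in place of hydrogen on an amine nitrogen in a ring. Among the compounds with values here, no measured pair shows this change on its own, so its size is uncertain. Because compound 1 gives only 27%, a move downward seems more likely than one upward. In this assay a drop of about a number 19 percentage points lower from compound 2 to compound 3 (beyond the scatter) is expected. Compound 3 is therefore estimated at 30%, between 15% and 50%.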

Compound 3, largest response reached (reported as percent of maximum), in percent of the reference or control that the assay uses: 13%
The estimate for compound 3 lay 17 percentage points above the measured number; the measured number lies below the stated range.
By their numbers in this assay, from the lowest: compound 3; then compound 1; then compound 2.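

In this assay, methyl in place of hydrogen on the amine nitrogen in a ring gives a number 36 percentage points lower from compound 2 to compound 3 (beyond the scatter), so even one added carbon at this position can change the maximal response substantially. The drawn configuration matters too, with a number 14 percentage points lower from compound 1 to compound 3 (beyond the scatter). This gap can only come from the arrangement in space, because of the following: the fact that compounds 1 and 3 differ only in the configuration as drawn

Going by these compounds, whether an ethyl or benzyl group on this nitrogen would lower the response further remains open. So does the size of the methyl step in the mirror-image series.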